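Cinnamoyl amide in a dodecyl threonine series

The compounds below may be only part of what the source reports. "The series", "measured", "known", "first", "only" and "open" are said of these compounds alone.

For the measured compounds named here, compound 2 `CCCCCCCCCCCCNC(=O)[C@@H](NC(=O)c1cc2ccccc2o1)[C@@H](C)O` is the only member of the series with a number in a functional assay on HepG2 cells (Homo sapiens) for cytotoxicity, read by MTT assay, with a stated time of 48 h (a lower number here means a stronger inhibitor, a higher number a weaker inhibitor), where compound 2 gives 22900 nM. Compound 1 `CCCCCCCCCCCCNC(=O)[C@@H](NC(=O)c1ccccc1)[C@@H](C)O` reaches only a limit of this assay, > 400000 nM, which is a limit and not a number (the limit of > 400000 nM in this assay, at which 1 of the 2 values shown sits). Going by the values given here, the one measured step, an at least 17-fold lower number from compound 1 to compound 2 (1.24 log units; beyond the scatter), shows that replacing the phenyl with the bicyclic 1-benzofuran-2-yl on the carbonyl carbon moved the number out of the limit region into the measurable range.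

Compound 3 `CCCCCCCCCCCCNC(=O)[C@@H](NC(=O)/C=C/c1ccccc1)[C@@H](C)O` carries 2-phenylethenyl in place of 1-benzofuran-2-yl on a carbonyl carbon. The 2-phenylethenyl keeps the phenyl of compound 1 but extends it by one double bond outside aromatic rings, so it is intermediate in extent between the phenyl of compound 1 and the 1-benzofuran-2-yl of compound 2. The step from compound 1 to compound 2 is the only one that bears on this change, and it was large; a partial return toward the limit of compound 1 is expected, so the number is expected to rise, with a real chance of a limit only.

The expected step is a 3.1-fold higher number from compound 2 to compound 3 (0.49 log units; beyond the scatter). The estimate for compound 3 in this assay is 70000 nM, with a range from 15000 nM to 400000 nM.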

Compound 3, half-maximal inhibitory concentration: > 200000 nM
Compound 3: only a limit was reported (the forecaster's own chance of this, stated with the estimate: 30%); middle value at least 2.8-fold (0.45 log units) away from the limit.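

In this assay, the 2-phenylethenyl on the carbonyl carbon does not hold the level of the 1-benzofuran-2-yl, and the change gives an at least 8.7-fold higher number from compound 2 to compound 3 (0.94 log units; beyond the scatter). Compound 3 reports only a limit, not a number: the limit of > 200000 nM in this assay, at which 1 of the 3 values shown sits. Of the three groups shown at this place, only the 1-benzofuran-2-yl gives a number, while the phenyl and the 2-phenylethenyl both end at limits, so the comparison between those two cannot be read and no order can be given for them.

The 1-benzofuran-2-yl differs from the 2-phenylethenyl in both its five-membered aromatic ring and its hydrogen-bond acceptor, and the compounds shown do not separate these two features, which a naphthalen-2-yl or a 1-benzothiophen-2-yl on the same carbonyl carbon would begin to do. Going by these compounds, whether the number of compound 2 depends on the dodecyl chain also remains open, and an octyl chain in its place, with the 1-benzofuran-2-yl kept, would test this.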